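A few compounds are considered here, and "the series" means these few. Any claim that something is new, unique, unknown or untested is made for them only; others in the source may bear on it.

Measured in a functional assay for inhibition, with Homo sapiens as the target; a higher number here means weaker binding, a lower number tighter binding:
- compound 1 `Cc1ccc(C#N)c(OC(C)(C)C2OCC(C/C=C\CCC(=O)O)C(c3cccnc3)O2)c1`: 15.9 nM
- compound 2 `CC(C)(Oc1ccc(F)cc1[N+](=O)[O-])C1OCC(C/C=C\CCC(=O)O)C(c2cccnc2)O1`: 2.51 nM
- compound 3 `CC(C)(Sc1ccccc1)C1OCC(C/C=C\CCC(=O)O)C(c2cccnc2)O1`: 200 nM

Compound 3, at 200 nM, holds the highest of the three numbers. Compound 4 `CC(C)(Cc1ccc(F)cc1C#N)C1OCC(C/C=C\CCC(=O)O)C(c2cccnc2)O1` differs from it as follows: a group of 10 heavy atoms (8 carbon, 1 nitrogen, 1 fluorine; one six-membered aromatic ring of carbon only) in place of a group of 7 heavy atoms (6 carbon, 1 sulfur; one six-membered aromatic ring of carbon only), on a saturated chain carbon bound to two saturated chain carbons and a saturated ring carbon.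

Two large measured steps bear on this change, a 13-fold higher number from compound 1 to compound 3 (1.10 log units; beyond the scatter) and an 80-fold higher number from compound 2 to compound 3 (1.90 log units; beyond the scatter). Each puts phenylsulfanyl at the same place and raises the number. The modest 6.3-fold lower number from compound 1 to compound 2 (0.80 log units; beyond the scatter) shows that the number also varies among the larger groups. Among the measured compounds shown here, no measured compound carries the entering group, so a clear fall, short of the full size of those steps, is expected. The expected change is an 8.0-fold lower number from compound 3 to compound 4 (0.90 log units; beyond the scatter). Compound 4 is estimated at 25 nM, with an expected range of 5 nM to 120 nM.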

Compound 4, dissociation constant: 2.19 nM
Compound 4: middle estimate off by 11-fold (1.06 log units), on the high side; the measured number lies below the stated range.
By their numbers in this assay, from the lowest: compounds 4 and 2 (each within the scatter of the next); then compound 1; then compound 3.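

In this assay the entering group at this saturated chain carbon gives a far lower number than phenylsulfanyl (a 91-fold lower number from compound 3 to compound 4 (1.96 log units; beyond the scatter)). The entering group holds no oxygen, yet it sits within the scatter of the group in compound 2 (a 1.1-fold lower number from compound 2 to compound 4 (0.06 log units; within the scatter)) and beats the group in compound 1 (a 7.3-fold lower number from compound 1 to compound 4 (0.86 log units; beyond the scatter)), so oxygen in this group is not required for a low number. Among the compounds shown here, compound 3 remains the only compound of the four with a number this high.

From the compounds shown here alone, the separate contributions of the nitrile and the fluorine remain open, as does the reading of an unsubstituted benzyl group or an amine at this carbon. No measured evidence accounts for these differences.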